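Second chloro on the core of compound 3

The source may report more compounds than this note shows. Statements on the series, on what has been measured and on what is new or still open speak of the compounds shown alone.

The series holds three measured compounds and one open one. Compound 1 `ClCc1ccccc1Cn1cnc2c(Cl)nc(Cl)nc21`, compound 2 `ClCc1cccc(Cn2cnc3c(Cl)ncnc32)c1` and compound 3 `ClCc1ccccc1Cn1cnc2ncnc(Cl)c21` were all tested in a functional assay on RXF 393 cells (Homo sapiens) for cytotoxicity, read by sulforhodamine B assay, with a stated time of 48 h; a higher number here means a weaker inhibitor of growth, a lower number a stronger inhibitor of growth. Compound 1 gives 100 nM; compound 2 gives 2290 nM; compound 3 gives 1650 nM. Compound 3 thus sits second highest of the three numbers: its nearest neighbour is compound 2, whose number is within the scatter of it, while compound 1 lies far below it, beyond the scatter. Compound 1 and compound 3 differ in more than one place, so their gap cannot be laid to a single change.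

Compound 4 `ClCc1ccccc1Cn1cnc2nc(Cl)nc(Cl)c21` is compound 3 with one alteration: chloro in place of hydrogen on an aromatic carbon, between two ring nitrogen atoms, meta to a chloro group and meta and para to a fused ring. Going by the values given here, no pair already measured isolates this change. Among the compounds with values here, the only pointer is that compound 1, the one measured compound carrying two chloro groups on the shared core, gives 100 nM, whereas the single-chloro compound 3 gives 1650 nM. That comparison is confounded by other differences between the two, so it is only a soft hint toward a lower number. A moderate downward step from compound 3 to compound 4 is expected, estimated at a 3.3-fold lower number from compound 3 to compound 4 (0.52 log units; beyond the scatter), with wide uncertainty. Compound 4 is accordingly estimated at 500 nM in this assay, within a range from 120 nM to 2500 nM.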

Compound 4, concentration for 50% growth inhibition: 1 nM
For compound 4 the middle estimate is 500-fold (2.70 log units) above the measured one; the whole stated range lies above it.
By their numbers in this assay, from the lowest: compound 4; then compound 1; then compounds 3 and 2 (each within the scatter of the next).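

In this assay, going by these compounds alone, a single chloro in place of hydrogen on the aromatic carbon between two ring nitrogen atoms gives a 1700-fold lower number from compound 3 to compound 4 (3.22 log units; beyond the scatter), a large step and the only one so far that isolates one change. The earlier compounds shown here offered only a confounded comparison, whereas this pair shows directly that the series responds very strongly to what occupies this carbon, meta to a chloro group on the same ring. The data on hand give no measured property or other evidence that would account for the size of this step.

Whether the gain is specific to chloro stays open, since the compounds shown do not say how an amine, a methoxy group, a methyl group or a fluoro group on this same carbon would compare with hydrogen and chloro. Also open, on these data alone, is how far the step depends on the other chloro group on the ring or on the chloromethyl group, neither of which varies across this pair.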